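The source may report more compounds than this note shows. Statements on the series, on what has been measured and on what is new or still open speak of the compounds shown alone.

Measured so far in an ADME assay on HEL cells (Homo sapiens) for cytotoxicity; a lower number here means that less compound is tolerated, a higher number that more compound is tolerated:
compound 1 `Cc1ccc(/C=N/NC(=O)COc2cccc3ccccc23)cc1` 80.1 ug/mL
compound 2 `O=C(COc1cccc2ccccc12)N/N=C/c1ccc(Cl)cc1` 100 ug/mL
compound 3 `O=C(COc1cccc2ccccc12)N/N=C/c1cccc(O)c1` 62.7 ug/mL

Compound 3 gives the lowest of the three numbers, yet every step to it lies within the scatter: a 1.3-fold lower number from compound 1 to compound 3 (0.11 log units; within the scatter) and a 1.6-fold lower number from compound 2 to compound 3 (0.20 log units; within the scatter). The three compounds therefore read as one group of similar tolerance. Compound 4 `O=C(COc1cccc2ccccc12)N/N=C/c1ccccc1Cl` differs from compound 3 in one place: 2-chlorophenyl in place of 3-hydroxyphenyl on a carbon with a double bond to nitrogen. The step from compound 2 to compound 3 bears most on it, since it also exchanges a chlorophenyl for the 3-hydroxyphenyl, and it was within the scatter; the step from compound 1 to compound 3 likewise. No step beyond the scatter is therefore expected for a 1.4-fold higher number from compound 3 to compound 4 (0.13 log units; within the scatter) in this assay. Compound 4 is estimated at 85 ug/mL, range 50 ug/mL to 140 ug/mL.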

Compound 4, half-maximal cytotoxic concentration: 62.7 ug/mL
Compound 4: the middle estimate sits 1.4-fold (0.13 log units) above what was measured; the range from low to high includes it.
By their numbers in this assay, from the lowest: compounds 3, 4, 1 and 2 (each within the scatter of the next).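

With no change at the digits printed from compound 3 to compound 4 (within the scatter) in this assay, the hydrogen-bond donor and acceptor of 3-hydroxyphenyl are absent from 2-chlorophenyl, and the number stays within the scatter. The chlorine's place on the ring also shows no step beyond the scatter, with a 1.6-fold lower number from compound 2 to compound 4 (0.20 log units; within the scatter), and the same holds against 4-methylphenyl, with a 1.3-fold lower number from compound 1 to compound 4 (0.11 log units; within the scatter). Nothing measured accounts for this flat picture.

All four compounds carry a phenyl group with no net charge here. From the compounds shown here alone, whether an amine or a carboxylic acid on that ring would give a step beyond the scatter remains open.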